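Thiophene Isomers in a Nucleoside Series: Cytotoxicity on Fibroblasts

The compounds below may be only part of what the source reports. "The series", "measured", "known", "first", "only" and "open" are said of these compounds alone.

Compound 1 `OC[C@H]1O[C@@H](n2cc(Cl)c3c(-c4cccs4)ncnc32)[C@H](O)[C@@H]1O` and compound 2 `OC[C@H]1O[C@@H](n2cc(Cl)c3c(-c4ccsc4)ncnc32)[C@H](O)[C@@H]1O` share one core and differ only in thiophen-3-yl in place of thiophen-2-yl on an aromatic carbon. In an ADME assay on BJ cells (Homo sapiens) for cytotoxicity, read by MTT assay, with a stated time of 72 h (a lower number here means that less compound is tolerated, a higher number that more compound is tolerated), compound 1 gives 4970 nM, and compound 2 gives 1720 nM, a step of a 2.9-fold lower number from compound 1 to compound 2 (0.46 log units; beyond the scatter). Compound 3 `CCCCCCCCCCCCCCCCCCOP(=O)(O)OC[C@H]1O[C@@H](n2ccc3c(-c4cccs4)ncnc32)[C@H](O)[C@@H]1O` carries a different core; how the two cores differ is not broken down here, and in this assay compound 3 stands at "not determined" (no result reported), so no number is available for it. Compound 4 `CCCCCCCCCCCCCCCCCCOP(=O)(O)OC[C@H]1O[C@@H](n2ccc3c(-c4ccsc4)ncnc32)[C@H](O)[C@@H]1O` differs from compound 3 by thiophen-3-yl in place of thiophen-2-yl on an aromatic carbon, the same change as between compounds 1 and 2. With no value for compound 3, the expectation for compound 4 rests only on compound 2 giving 1720 nM and on the step of a 2.9-fold lower number from compound 1 to compound 2 (0.46 log units; beyond the scatter). Compound 4 is therefore estimated at 1500 nM in this assay, expected between 300 nM and 8000 nM.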

Compound 4, half-maximal cytotoxic concentration: > 50000 nM
Compound 4 ended at the assay's limit; the forecaster's own chance of this, stated with the estimate: 25%; at least 33-fold (1.52 log units) between middle value and limit.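

In this assay compound 4 gives > 50000 nM, a limit and not a number, and with compound 3 lacking a value, no step can be read between them. As far as these compounds go, whether thiophen-3-yl in place of thiophen-2-yl acts on their core as it does between compound 1 and compound 2 stays open.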